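Swapping dimethylamino for piperidin-1-yl: expected cytotoxicity shift

The source may hold more compounds than are shown below. What is called first, only, known or untested is meant among the compounds shown, and "the series" means these compounds.

In an ADME assay on L6 cells (Rattus norvegicus) for cytotoxicity (a lower number here means a stronger inhibitor, a higher number a weaker inhibitor), compound 1 (`O=C(CCN1CCCC1)OC1CC2(N3CCCCC3)CC(c3ccccc3)C1C(c1ccccc1)C2`) gives 12500 nM and compound 2 (`CN(C)C12CC(OC(=O)CCN3CCCCC3)C(C(c3ccccc3)C1)C(c1ccccc1)C2`) gives 25800 nM. Compound 2 therefore holds the higher of the two numbers, making it the weaker inhibitor of this pair, and the gap lies beyond the usual scatter.

The next change starts from compound 2. In compound 3 (`O=C(CCN1CCCCC1)OC1CC2(N3CCCCC3)CC(c3ccccc3)C1C(c1ccccc1)C2`), piperidin-1-yl stands in place of dimethylamino on a saturated ring carbon: piperidin-1-yl in place of dimethylamino on a saturated ring carbon. The ring bearing the ((2-(piperidin-1-yl)ethyl)carbonyl)oxy group is otherwise untouched.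

Among the compounds with values here, no measured step isolates this replacement, so the expectation has little to rest on. The only other reference point is compound 1 at 12500 nM, and the estimate is therefore drawn from compound 2 toward that value. In this assay, a moderate move to a lower number is expected, with the estimated change being a 1.8-fold lower number from compound 2 to compound 3 (0.27 log units; within the scatter). A result within the scatter would not be surprising. For compound 3 the estimated value is 14000 nM, with an expected range of 6000 nM to 30000 nM.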

Compound 3, half-maximal inhibitory concentration: 54600 nM
Beside the measured number, compound 3's estimate is 3.9-fold (0.59 log units) below it, outside the stated range (above it).
By their numbers in this assay, from the lowest: compound 1; then compound 2; then compound 3.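

In this assay, the series now has its first two single-place steps, and both go the same way: with piperidin-1-yl in place of dimethylamino on the saturated ring carbon, the result is a 2.1-fold higher number from compound 2 to compound 3 (0.33 log units; beyond the scatter), and with piperidin-1-yl in place of pyrrolidin-1-yl on the saturated chain carbon, two bonds along the chain from a carbonyl carbon, it is a 4.4-fold higher number from compound 1 to compound 3 (0.64 log units; beyond the scatter). Neither site is therefore neutral to the amine it carries, and the chain-site step is the larger of the two, while compound 3, which carries piperidin-1-yl at both sites, is the weakest inhibitor of the three in this read-out. Nothing available explains either shift or separates the contribution of the added ring atoms from that of the amine's identity.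

As far as these compounds go, each site still rests on one step, so it remains open whether the upward move follows piperidin-1-yl specifically or would extend to other amines. A morpholin-4-yl group or a primary amine on the saturated ring carbon, or a longer chain between the carbonyl carbon and the terminal amine, would show how far this trend holds.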